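A few compounds are considered here, and "the series" means these few. Any claim that something is new, unique, unknown or untested is made for them only; others in the source may bear on it.

In an assay on isolated protein for inhibition of Amine oxidase [flavin-containing] A (Homo sapiens), read by spectrophotometry (a lower number here means a stronger inhibitor, a higher number a weaker inhibitor), compound 1 `COc1ccc(/C=N/Nc2nc3ccccc3nc2Cc2ccccc2)cc1OC` gives 56 nM. Compound 2 `COc1cc(/C(C)=N/Nc2nc3ccccc3nc2Cc2ccccc2)cc(OC)c1OC` gives 29 nM, and compound 3 `COc1ccc(/C(C)=N/Nc2nc3ccccc3nc2Cc2ccccc2)cc1` gives 89 nM. Compound 1 thus sits between the other two numbers, yet each gap stays within the scatter of repeated measurements, so none of the three can be set above or below another. No single change connecting two measured compounds is available to calibrate the next one. Compound 4 `Clc1ccc(/C=N/Nc2nc3ccccc3nc2Cc2ccccc2)cc1` differs from compound 1 in one place: 4-chlorophenyl in place of 3,4-dimethoxyphenyl on a carbon with a double bond to nitrogen. Without a measured step of this kind, the expectation is a step no larger than the scatter, in either direction. Compound 4 is accordingly estimated at 45 nM, in a range from 15 nM to 150 nM. The expected step is a 1.2-fold lower number from compound 1 to compound 4 (0.09 log units; within the scatter).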

Compound 4, half-maximal inhibitory concentration: 76 nM
Compound 4: middle estimate off by 1.7-fold (0.23 log units), on the low side; the range from low to high includes it.
By their numbers in this assay, from the lowest: compounds 2, 1, 4 and 3 (each within the scatter of the next, the first and the last beyond it).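

In this assay, going by these compounds alone, the change at this position gives a 1.4-fold higher number from compound 1 to compound 4 (0.13 log units; within the scatter), the first single-place step. On a carbon with a double bond to nitrogen, 4-chlorophenyl can therefore stand in for 3,4-dimethoxyphenyl without a change beyond the scatter, even though the entering group has no hydrogen-bond acceptors and the leaving group does. No available evidence bears on this result. On these data alone, it remains open whether this flat response would hold for an aryl group carrying a carboxylic acid or an amine, and whether plain phenyl would behave the same way.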